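Fluoro to methyl swap on the six-membered ring

The compounds below may be only part of what the source reports. "The series", "measured", "known", "first", "only" and "open" are said of these compounds alone.

Among the compounds with values here, compound 2 `O=C(O)Cc1sc(C(c2ccc(F)cc2)c2ccc(F)cc2)nc1-c1ccnc(F)c1` gives 4.7 nM in an in vitro functional assay on HEK285-7 cells for antagonist activity at prostaglandin D2 receptor 2 (Homo sapiens), read by BRET and beta-arrestin recruitment (on this read-out higher numbers stand for weaker inhibition and lower numbers for stronger inhibition), the lowest of the two numbers so far, while compound 1 `O=C(O)Cc1sc(C(c2ccc(F)cc2)c2ccc(F)cc2)nc1-c1ccoc1` gives 130 nM in this assay; the step of a 28-fold lower number from compound 1 to compound 2 (1.44 log units; beyond the scatter) exchanged one whole ring for another. Compound 3 `Cc1cc(-c2nc(C(c3ccc(F)cc3)c3ccc(F)cc3)sc2CC(=O)O)ccn1` differs from compound 2 by methyl in place of fluoro on an aromatic carbon. Within the data shown here, no measured step touches that substituent, and the single known step concerns a ring exchange rather than fluoro against methyl. The step of a 1.7-fold higher number from compound 2 to compound 3 (0.23 log units; within the scatter) is therefore expected to stay within the scatter. Compound 3 is estimated at 8 nM, with a range from 2.5 nM to 25 nM.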

Compound 3, half-maximal inhibitory concentration: 53 nM
Compound 3: middle estimate off by 6.6-fold (0.82 log units), on the low side; measured number above the stated range.
By their numbers in this assay, from the lowest: compound 2; then compound 3; then compound 1.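

Next to the ring nitrogen, the substituent carries much of the result: methyl in place of fluoro gives an 11-fold higher number from compound 2 to compound 3 (1.05 log units; beyond the scatter) and so the low number of 2-fluoropyridin-4-yl does not carry over to 2-methylpyridin-4-yl. Against furan-3-yl, the methylated ring gives a 2.5-fold lower number from compound 1 to compound 3 (0.39 log units; beyond the scatter) and so keeps a smaller advantage than the fluorinated ring. Nothing available accounts for the difference between fluoro and methyl.

As far as these compounds go, whether the low number is particular to fluoro remains open. Chloro, methoxy or an amine on the same carbon would help to settle this.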